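The source may hold more compounds than are shown below. What is called first, only, known or untested is meant among the compounds shown, and "the series" means these compounds.

Compound 1 `O=c1[nH]nc(C[S+]([O-])C(c2ccccc2)c2ccccc2)s1` and compound 2 `Cc1noc(C[S+]([O-])C(c2ccccc2)c2ccccc2)n1` share a core that carries a five-membered aromatic ring on a saturated chain carbon bound to a sulfur. In an assay on HEK293 cells for inhibition of sodium-dependent dopamine transporter (Homo sapiens), read by scintillation counting, with stated times of 5 min and 1 min (a higher number here means a weaker inhibitor, a lower number a stronger inhibitor), compound 1 gives 38100 nM, and in this assay compound 2 gives 56700 nM. Within the data shown here, compound 2 stands at the highest of the two numbers so far, with compound 1 its only neighbour, since a 1.5-fold higher number from compound 1 to compound 2 (0.17 log units; within the scatter).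

Compound 3 `[O-][S+](Cc1ccncc1)C(c1ccccc1)c1ccccc1` differs from compound 2 in that (pyridin-4-yl in place of 3-methyl-1,2,4-oxadiazol-5-yl on a saturated chain carbon bound to a sulfur). Among the measured compounds shown here, the only measured step that bears on this kind of swap of the ring on that chain carbon is a 1.5-fold higher number from compound 1 to compound 2 (0.17 log units; within the scatter), which exchanged one five-membered aromatic ring for another without moving beyond the scatter. Nothing measured speaks to a six-membered ring in this place, so no step beyond the scatter is expected either way; the step of a 1.1-fold lower number from compound 2 to compound 3 (0.05 log units; within the scatter) is what the estimate implies. Compound 3 is therefore expected to give 50000 nM in this assay, within a range of 15000 nM to 150000 nM.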

Compound 3, half-maximal inhibitory concentration: 63500 nM
Estimate against measurement, compound 3: 1.3-fold (0.10 log units) below; the measured number falls inside the stated range.
By their numbers in this assay, from the lowest: compounds 1, 2 and 3 (each within the scatter of the next).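

On a saturated chain carbon bound to a sulfur, pyridin-4-yl in place of 3-methyl-1,2,4-oxadiazol-5-yl gives a 1.1-fold higher number from compound 2 to compound 3 (0.05 log units; within the scatter) in this assay, so this position now has a comparison between a six-membered and a five-membered aromatic ring, where the earlier step covered only five-membered rings. The other step to the new ring reads the same way, with a 1.7-fold higher number from compound 1 to compound 3 (0.22 log units; within the scatter), so neither change of ring size moves the number beyond the scatter. No evidence at hand bears on why these ring exchanges leave the number within the scatter.

From the compounds shown here alone, whether an amine or a carboxylic acid on this chain carbon, or a longer chain carrying the ring, would give a step beyond the scatter remains open. Going by these compounds, the rest of the shared core stays fixed across all three compounds, so its contribution also remains open.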